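The compounds below may be only part of what the source reports. "The series", "measured", "known", "first", "only" and "open" are said of these compounds alone.

Measured compounds:
Compound 1 `CCCCCCCCCCCC(=O)NC(CCCCN)C(=O)NCCCCCCCCCCCC(=O)NC(CCCCN)C(=O)O`; in an ADME assay on MDCK cells (Canis lupus familiaris) for cytotoxicity, read by resazurin assay, with a stated time of 3.5 h (a lower number here means a stronger inhibitor, a higher number a weaker inhibitor), compound 1 gives > 100000 nM, which is a limit.
Compound 2 `NCCCCCCCCCCCC(=O)NC(CCCCN)C(=O)NCCCCCCCCCCCC(=O)NC(CCCCN)C(=O)O`; in this assay compound 2 gives > 150000 nM, which is a limit.
Compound 3 `NCCCCC(N)C(=O)NCCCCCCCCCCCC(=O)NC(CCCCN)C(=O)O`; in this assay compound 3 gives > 800000 nM, which is a limit.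

Compound 2 stands only as a limit in this assay, and the two further values shown are limits as well, so no number places compound 2 against compound 1 or compound 3. Going by the values given here, the single step among the measured compounds, a step that the two limits leave unreadable from compound 1 to compound 2, runs between two limits and its size cannot be read. What is known reduces to three limits: the limit of > 100000 nM in this assay, at which 1 of the 3 values shown sits, the limit of > 150000 nM in this assay, at which 1 of the 3 values shown sits, and (the limit of > 800000 nM in this assay, at which 1 of the 3 values shown sits).

Compound 4 `NCCCCC(N)C(=O)NCCCCCCCCCCCC(=O)NC(CCCCN)C(=O)NCCCCCCCCCCCC(=O)NC(CCCCN)C(=O)O` differs from compound 2 by (1,5-diaminopentyl)carbonyl in place of hydrogen on an amine nitrogen. Among the compounds with values here, no measured step bears on an addition of this kind; the step from compound 1 to compound 2 is the only one available and is unreadable. The expectation in this assay is therefore a value that again sits at the limit, with no step beyond the scatter to be read. Compound 4 is estimated at 150000 nM, with an expected range from 50000 nM to 1000000 nM. The step from compound 2 to compound 4 is expected as a number no higher from compound 2 to compound 4 (the limit leaves the size open), most likely reported again only as a limit.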

Compound 4, half-maximal inhibitory concentration: > 400000 nM
Compound 4 was reported as a limit; the forecaster's own chance of this, stated with the estimate: 85%; middle value at least 2.6-fold (0.42 log units) away from the limit.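

In this assay compound 4 gives > 400000 nM, which is a limit. Its steps from compound 2 and from compound 1 both run between limits, so neither can be read. The compounds shown leave open where any of the four actual values lies and whether (1,5-diaminopentyl)carbonyl in place of hydrogen on an amine nitrogen changes the read-out at all.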